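Phenylethenyl in Place of Nitrophenyl: Vero Cell Cytotoxicity

This account rests on a few compounds, and the source may have more. Where it says the series, first, only, none or still open, it means among the compounds named here.

Measured so far:
Compound 1, `CN(C)c1ccc(C2CC(c3cc4ccccc4o3)=NN2C(=O)c2ccncc2)cc1`, gives > 210000 nM in an ADME assay on Vero cells (Chlorocebus sabaeus) for cytotoxicity, read by MTT assay, with a stated time of 72 h (on this read-out lower numbers stand for stronger inhibition and higher numbers for weaker inhibition), which is a limit of the assay and not a number.
Compound 2, `CCn1cc(C(=O)N2N=C(c3cc4ccccc4o3)CC2c2cccc([N+](=O)[O-])c2)c(=O)c2ccc(C)nc21`, gives > 164000 nM in this assay, again a limit of the assay rather than a number.

Among the compounds with values here, compound 2 therefore stands at the limit of > 164000 nM in this assay, at which 1 of the 2 values shown sits, while the only other value, that of compound 1, sits at the limit of > 210000 nM in this assay, at which 1 of the 2 values shown sits. Within the data shown here, both values are limits, so no step between the measured compounds can be given, and nothing in these two readings separates the compounds from each other.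

The unmeasured compound 3, `CCn1cc(C(=O)N2N=C(c3cc4ccccc4o3)CC2/C=C/c2ccccc2)c(=O)c2ccc(C)nc21`, differs from compound 2 in one place: 2-phenylethenyl in place of 3-nitrophenyl on a saturated ring carbon. Among the measured compounds shown here, compound 2 gives only a limit, so there is no measured step on which to base a direction, and no step beyond the scatter is expected in this assay. The step of an at least 1.0-fold lower number from compound 2 to compound 3 (0.03 log units; that floor lies within the scatter) is an estimate resting on compound 2 alone. Compound 3 is expected to give 150000 nM, with a range from 50000 nM to 300000 nM, and most likely once more only a limit.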

Compound 3, half-maximal inhibitory concentration: > 168000 nM
Compound 3 was reported as a limit (the forecaster's own chance of this, stated with the estimate: 70%); middle value at least 1.1-fold (0.04 log units) from the limit.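

In this assay compound 3 gives > 168000 nM, a limit of the assay and not a number. Within the data shown here, compound 2 also gives only a limit, so no step between compound 2 and compound 3 can be read. The compounds shown leave open whether 2-phenylethenyl in place of 3-nitrophenyl on a saturated ring carbon changes this read-out at all.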